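This account rests on a few compounds, and the source may have more. Where it says the series, first, only, none or still open, it means among the compounds named here.

Working notes on the series. The shared core carries a chain ending in a guanidine-type or urea-type tail, and the stomach read-out is given by a functional assay on the whole organism (stomach) with Rattus norvegicus as the target; a higher number here means that more compound is needed for the effect, a lower number that less compound is needed. Compound 1 `N#CNC(=N)NCCCn1nc(-c2ccccc2)ccc1=O` gives only a limit in this assay, > 100 mg/kg. Compound 2 `CC/N=C(/NC#N)NCCCCn1nc(-c2ccccc2)ccc1=O` gives 92 mg/kg, and compound 3 `CN(C)/C(=N/CCCn1nc(-c2ccccc2)ccc1=O)NC#N` gives 53 mg/kg. Among the numbers shown, compound 3 stands lowest of the two, with compound 2 nearest at a gap that lies within the scatter; the one remaining value is the limit of compound 1. Among the measured compounds shown here, the only step within one change is an at least 1.8-fold lower number from compound 1 to compound 3 (0.27 log units; that floor lies within the scatter), and its floor lies within the scatter, so it cannot be read as a real shift.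

Compound 4 `C=CCNC(=S)NCCCCn1nc(-c2ccccc2)ccc1=O` is to be measured in this assay. It differs from compound 3 by a group of 8 heavy atoms (5 carbon, 2 nitrogen, 1 sulfur; no ring) in place of a group of 8 heavy atoms (4 carbon, 4 nitrogen; no ring), on a saturated chain carbon, three bonds along the chain from an aromatic nitrogen. For the measured compounds named here, no measured step touches the exchange of the cyanoguanidine tail for a thiourea tail, so no direction is supported by the data here. Both numbers shown lie close together, which makes a large departure from compound 3 unlikely but not excluded. The expectation for compound 4 is therefore a step of a 1.1-fold higher number from compound 3 to compound 4 (0.05 log units; within the scatter), within the scatter. Compound 4 is estimated at 60 mg/kg, with a range from 25 mg/kg to 150 mg/kg.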

Compound 4, dose for half-maximal effect: > 100 mg/kg
Compound 4 was reported as a limit (the forecaster's own chance of this, stated with the estimate: 20%); middle value at least 1.6-fold (0.22 log units) away from the limit.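

Exchanging the group of 8 heavy atoms (4 carbon, 4 nitrogen) for the group of 8 heavy atoms (5 carbon, 2 nitrogen, 1 sulfur), on a saturated chain carbon, three bonds along the chain from an aromatic nitrogen, gives in this assay an at least 1.8-fold higher number from compound 3 to compound 4 (0.27 log units; that floor lies within the scatter), so this exchange, new to the series, shows no real shift. On an amine nitrogen, the exchange of one group for another gives an at least 1.0-fold higher number from compound 2 to compound 4 (0.03 log units; that floor lies within the scatter), so here too the change cannot be told apart from the scatter. Compound 4 gives only a limit, as compound 1 does, and the step between those two cannot be read: the limit of > 100 mg/kg in this assay, at which 2 of the 4 values shown sit.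

From the compounds shown here alone, with no number behind either limit, the real size of the step away from the sulfur-bearing tail remains unknown. Going by these compounds, how a urea tail with oxygen in place of the sulfur, or a longer chain carrying the same tail, would read in this assay stays open.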